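Oxime series: halogen for methoxy, cytotoxicity expectation

This account rests on a few compounds, and the source may have more. Where it says the series, first, only, none or still open, it means among the compounds named here.

Compound 3 `COc1ccc(/C=C/C(=N\O)c2ccc(OC)cc2)cc1` gives 2170000 nM in an ADME assay on cells (Mus musculus, strain Balb/c) for cytotoxicity, read by MTT assay, with a stated time of 48 h (on this read-out higher numbers stand for lower toxicity in this test and lower numbers for higher toxicity in this test), the highest of the three numbers measured: compound 2 `COc1ccc(C(/C=C/c2ccc(Br)cc2)=N/O)cc1` gives 737000 nM and compound 1 `COc1ccc(C(/C=C/c2ccc(F)cc2)=N/O)cc1` gives 13500 nM. The step of a 2.9-fold higher number from compound 2 to compound 3 (0.47 log units; beyond the scatter) is modest, while the step of a 160-fold higher number from compound 1 to compound 3 (2.21 log units; beyond the scatter) and the step of a 55-fold higher number from compound 1 to compound 2 (1.74 log units; beyond the scatter) are large, all pointing the same way: a methoxy in place of a halogen raised the number, and fluoro gave the lowest number of all.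

Compound 4 `COc1ccc(/C=C/C(=N\O)c2ccc(Cl)cc2)cc1` differs from compound 3 by chloro in place of methoxy on an aromatic carbon. This change sits on a different aromatic ring of the shared core from the ring where the measured steps took place, so they bear on it only by analogy. Reading them as the best guide available, removing a methoxy in favour of a halogen is expected to lower the number in this assay, and chloro should fall between the bromo result of compound 2 and the fluoro result of compound 1. The expected step is an 11-fold lower number from compound 3 to compound 4 (1.04 log units; beyond the scatter), a decrease beyond the scatter but with wide uncertainty. Compound 4 is therefore estimated at 200000 nM, with a range from 30000 nM to 1500000 nM.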

Compound 4, half-maximal cytotoxic concentration: 24300 nM
Compound 4: middle estimate off by 8.2-fold (0.92 log units), on the high side; the whole stated range lies above it.
By their numbers in this assay, from the lowest: compounds 1 and 4 (each within the scatter of the next); then compound 2; then compound 3.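

In this assay, the step of an 89-fold lower number from compound 3 to compound 4 (1.95 log units; beyond the scatter) shows that the site on an aromatic carbon para to a large group, on the other aromatic ring of the shared core from the earlier changes, is itself highly responsive to swapping methoxy for a halogen, so the number does not depend only on the ring varied in compounds 1, 2 and 3. Going by these compounds alone, the direction matches the earlier steps, where methoxy carried the higher number and the halogen the lower one, but the size does not carry over evenly: the step of a 2.9-fold higher number from compound 2 to compound 3 (0.47 log units; beyond the scatter) is modest, whereas the new one is large, and these two steps differ in both halogen and site, so the difference cannot be assigned to either. No measured evidence on the cause of the new step is available here.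

The compounds shown leave open whether the drop at this site follows from the arrival of chloro or from the loss of methoxy, which fluoro or bromo at the same site would help separate. They also leave open how this site would respond to a hydroxyl, an amine or a longer alkoxy chain such as ethoxy.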